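The source may hold more compounds than are shown below. What is called first, only, known or untested is meant among the compounds shown, and "the series" means these compounds.

Measured compounds in an ADME assay on SW480 cells (Homo sapiens) for cytotoxicity, read by MTT assay, with a stated time of 72 h; a lower number here means a stronger inhibitor, a higher number a weaker inhibitor:

compound 1 `Cc1ccc(NC(=O)c2cccc(/C=C3\CC(=O)N(c4ccccc4)C3=O)c2)cc1` — > 100000 nM
compound 2 `CCCCNC(=O)c1cccc(/C=C2\CC(=O)N(Cc3ccccc3)C2=O)c1` — > 100000 nM
compound 3 `CCCCCN1C(=O)C/C(=C\c2cccc(C(=O)Nc3cccc(F)c3)c2)C1=O` — > 100000 nM

Compound 1, with the structure `Cc1ccc(NC(=O)c2cccc(/C=C3\CC(=O)N(c4ccccc4)C3=O)c2)cc1`, shows no measurable effect in this assay: its value of > 100000 nM is a limit of the assay and not a number. The same holds for compound 2, whose value > 100000 nM is also a limit. Compound 3 likewise reaches only a limit, > 100000 nM. So compound 1 cannot be placed in any order against the other two; all that the numbers say is the limit of > 100000 nM in this assay, at which 3 of the 3 values shown sit.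

The compound that has not yet been measured is compound 4, `O=C(Nc1ccc(Cl)cc1)c1cccc(/C=C2\CC(=O)N(c3ccccc3)C2=O)c1`. Set against compound 1 it differs by chloro in place of methyl on an aromatic carbon, para to a large group on the six-membered aromatic ring of carbon only. Among the measured compounds shown here, every measured compound here sits at the limit, so no step is available to show how such a change moves this assay. With nothing beyond the scatter to go on, compound 4 is expected to behave much like compound 1, so that the step of a number no higher from compound 1 to compound 4 (the limit leaves the size open) is expected to be none beyond the scatter. Compound 4 is therefore estimated at 100000 nM, within 40000 nM to 250000 nM, most probably again reported only as a limit.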

Compound 4, half-maximal inhibitory concentration: > 100000 nM
Compound 4: a limit, no number; the forecaster's own chance of this, stated with the estimate: 85%; the middle value sits exactly at the limit.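

In this assay compound 4 gives > 100000 nM which is a limit of the assay and not a number. Compound 1 gives > 100000 nM which is also a limit, so no step can be read from compound 1 to compound 4. The compounds shown leave open whether any change on the shared core moves this read-out at all: the limit of > 100000 nM in this assay, at which 4 of the 4 values shown sit.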